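Toward a Less Toxic Analog of Compound 2

The compounds below may be only part of what the source reports. "The series", "measured", "known", "first", "only" and "open" are said of these compounds alone.

Compound 1 `Cc1ccc(NC(=O)CSc2nncnc2-c2cccc3ccccc23)c(Br)c1`: 166000 nM
Compound 2 `O=C(CSc1nncnc1-c1ccccc1Cl)c1ccc(Cl)c(Cl)c1`: 33000 nM
Compound 3 `CCOC(=O)c1ccc(NC(=O)CSc2nncnc2-c2ccccc2Cl)c(Br)c1`: 69000 nM

These three compounds were tested in an ADME assay on MT4 cells (Homo sapiens) for cytotoxicity, read by MTT assay; on this read-out higher numbers stand for lower toxicity in this test and lower numbers for higher toxicity in this test. Compound 2 gives the lowest number of the three in this assay, meaning it is the most toxic of this set; compound 3 sits nearest to it, beyond the scatter, and compound 1 lies furthest away, also beyond the scatter.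

Compound 4 `O=C(CSc1nncnc1-c1ccccc1Cl)Nc1ccccc1F` has not yet been measured in this assay. It differs from compound 2 in one place: (2-fluorophenyl)amino in place of 3,4-dichlorophenyl on a carbonyl carbon. After this change, compound 4 resembles compounds 1 and 3 more closely than compound 2 does, and both of those give higher numbers than compound 2. Going by the values given here, no step between two measured compounds shows this exact change, so the expectation rests on that resemblance alone.

Compound 4 is therefore expected to give a higher number than compound 2, a step of a 2.4-fold higher number from compound 2 to compound 4 (0.38 log units; beyond the scatter), beyond the scatter. The estimated value of compound 4 in this assay is 80000 nM, with a range from 30000 nM to 200000 nM.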

Compound 4, half-maximal cytotoxic concentration: 98000 nM
Estimate against measurement, compound 4: 1.2-fold (0.09 log units) below, within the range that was stated.
By their numbers in this assay, from the lowest: compound 2; then compounds 3, 4 and 1 (each within the scatter of the next, the first and the last beyond it).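

In this assay, placing (2-fluorophenyl)amino instead of 3,4-dichlorophenyl on the carbonyl carbon gives a 3.0-fold higher number from compound 2 to compound 4 (0.47 log units; beyond the scatter) and so moves the read-out toward lower toxicity in this test. Going by these compounds alone, the step is modest but beyond the scatter, and it is the first comparison in this set between compounds that differ in only one place, so it shows that the group at this position can shift the read-out. No available measurement explains why the number rises.

The change brings in a nitrogen with its amide hydrogen and replaces two chlorines with one fluorine, and the compounds shown cannot separate these parts. From the compounds shown here alone, it also remains open how plain phenylamino, a morpholine amide or a carboxylic acid at this carbonyl carbon would read.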